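This account rests on a few compounds, and the source may have more. Where it says the series, first, only, none or still open, it means among the compounds named here.

The account begins with a functional assay on HCT-15 cells (Homo sapiens) for cytotoxicity, read by CCK-8 assay; a higher number here means a weaker inhibitor, a lower number a stronger inhibitor. Compound 1 `Oc1ccccc1-c1cc(-c2cccs2)cc(-c2ccccc2O)n1` stands in this assay only at a limit of the assay: in this assay compound 1 gives > 50000 nM, a limit and not a number. Compound 2 `Oc1cccc(-c2cc(-c3cccs3)cc(-c3ccccc3O)n2)c1` gives in this assay > 50000 nM, also a limit. Compound 3 `Oc1ccc(-c2cc(-c3cccs3)cc(-c3ccccc3O)n2)cc1` gives in this assay > 50000 nM, again a limit. The three steps a step that the two limits leave unreadable from compound 1 to compound 2, a step that the two limits leave unreadable from compound 1 to compound 3 and a step that the two limits leave unreadable from compound 2 to compound 3 therefore cannot be read in size or direction, because of the limit of > 50000 nM in this assay, at which 3 of the 3 values shown sit.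

Compound 4 `Oc1ccccc1-c1cc(-c2ccsc2)cc(-c2ccccc2O)n1` differs from compound 1 in one place: thiophen-3-yl in place of thiophen-2-yl on an aromatic carbon. Among the compounds with values here, none of the measured steps touches the thiophene; all three move the hydroxyl on the phenyl groups and leave the thiophen-2-yl in place, so no measured step bears directly on this change. With every measured compound at the limit, the only expectation that the data support is that compound 4 will also be reported at the limit. Compound 4 is therefore estimated in this assay at 80000 nM, within a range from 30000 nM to 300000 nM. The step expected is a step that the limit leaves unreadable from compound 1 to compound 4, which means no readable change.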

Compound 4, half-maximal inhibitory concentration: > 50000 nM
Compound 4: a limit, no number; the forecaster's own chance of this, stated with the estimate: 85%; the middle value is on the limit's open side.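

In this assay compound 4 gives > 50000 nM, a limit and not a number. No step from compound 1 to compound 4 can therefore be read, because: the limit of > 50000 nM in this assay, at which 4 of the 4 values shown sit.

The compounds shown leave open whether moving the hydroxyl or the thiophene attachment changes potency at all.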